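Amide to Sulfonamide on a Shared Chalcone-Benzimidazole Core

The compounds below may be only part of what the source reports. "The series", "measured", "known", "first", "only" and "open" are said of these compounds alone.

Measured so far in a functional assay on 143B cells (Homo sapiens) for antiproliferative activity, read by MTT assay, with a stated time of 48 h; a lower number here means a stronger inhibitor, a higher number a weaker inhibitor:
- compound 1 `O=C(Nc1cccc(/C=C/C(=O)c2nc3ccccc3[nH]2)c1)c1cccc(Cl)c1` gives 3370 nM
- compound 2 `O=C(/C=C/c1cccc(NC(=O)c2ccccc2Br)c1)c1nc2ccccc2[nH]1` gives 6050 nM
- compound 3 `COc1ccc(C(=O)Nc2cccc(/C=C/C(=O)c3nc4ccccc4[nH]3)c2)cc1` gives 6330 nM

Compound 3 has the highest of the three numbers in this assay, but none of the gaps separates it from the others: the step of a 1.9-fold higher number from compound 1 to compound 3 (0.27 log units; within the scatter) and the step of a 1.0-fold higher number from compound 2 to compound 3 (0.02 log units; within the scatter) both stay within the scatter, as does a 1.8-fold higher number from compound 1 to compound 2 (0.25 log units; within the scatter). The three compounds share one core and differ only in the aromatic ring attached to the carbonyl of the amide, and changing that ring has so far moved nothing beyond noise.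

Compound 4 `O=C(/C=C/c1cccc(NS(=O)(=O)c2ccccc2Cl)c1)c1nc2ccccc2[nH]1` goes further. The change is (2-chlorophenyl)sulfonyl in place of (4-methoxyphenyl)carbonyl on a nitrogen on an aromatic ring. For the measured compounds named here, two things move at once: the ring substituent, for which the measured steps above suggest little effect, and the linker itself, from a carbonyl to a sulfonyl, for which no measured step exists. Given that no change so far has left the scatter, the expected step of a 1.3-fold lower number from compound 3 to compound 4 (0.10 log units; within the scatter) is small, with a wide range to cover the untested linker. Compound 4 is therefore estimated at 5000 nM, between 1500 nM and 20000 nM.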

Compound 4, half-maximal inhibitory concentration: 4790 nM
Compound 4: the middle estimate sits 1.0-fold (0.02 log units) above what was measured; the range from low to high includes it.
By their numbers in this assay, from the lowest: compounds 1, 4, 2 and 3 (each within the scatter of the next).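

The sulfonyl linker is new here, and in this assay replacing the carbonyl, together with the ring attached to it, leaves every step within the scatter: a 1.3-fold lower number from compound 3 to compound 4 (0.12 log units; within the scatter), a 1.3-fold lower number from compound 2 to compound 4 (0.10 log units; within the scatter) and a 1.4-fold higher number from compound 1 to compound 4 (0.15 log units; within the scatter). So on this nitrogen, a change to the linker itself has joined the ring changes in producing no step beyond noise, at least for these four compounds. No supporting data are available to explain this result.

For the compounds shown here, the effect of the linker alone remains open, as no pair here keeps the ring the same while swapping carbonyl for sulfonyl; (2-chlorophenyl)carbonyl on this nitrogen would give that comparison. Also open, as far as these compounds go, is whether a different kind of group here, such as a carboxylic acid on the ring or a longer chain in place of the ring, would move the number beyond the scatter.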